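Cyclopropylmethyl in place of the fluorobenzyl arm

The source may report more compounds than this note shows. Statements on the series, on what has been measured and on what is new or still open speak of the compounds shown alone.

Compound 1 `O=C(C1CC1)N1CCN(Cc2nc3ccccc3n2Cc2ccccc2C(F)(F)F)CC1` gives 56.3% in an assay on isolated protein for inhibition of aldehyde dehydrogenase 1A1 (Homo sapiens), read by spectrophotometry, tested at 10 uM; on this read-out lower numbers stand for less inhibition and higher numbers for more inhibition at the one concentration tested (going by the name of the read-out). Compound 2 `COc1cccc(Cn2c(CN3CCN(C(=O)C4CC4)CC3)nc3ccccc32)c1` gives 44.4%. Compound 3 `O=C(C1CC1)N1CCN(Cc2nc3ccccc3n2Cc2ccc(F)cc2)CC1` gives 32.7%.

Compound 3 stands lowest of the three, below compound 2 by a number 11.7 percentage points lower from compound 2 to compound 3 (beyond the scatter) and below compound 1 by a number 23.6 percentage points lower from compound 1 to compound 3 (beyond the scatter). Compound 4 `O=C(C1CC1)N1CCN(Cc2nc3ccccc3n2CC2CC2)CC1` differs from compound 3 by cyclopropyl in place of 4-fluorophenyl on a saturated chain carbon bound to an aromatic nitrogen. Within the data shown here, the two steps ending at compound 3 both swap one substituted phenyl for another on that chain carbon; no measured step removes the aromatic ring there, so they bear on the change only loosely. Those steps ran downward each time, and a further drop beyond the scatter is expected, though its size is uncertain. Compound 4 is estimated at 22% (range 5% to 40%), a step of a number 10.7 percentage points lower from compound 3 to compound 4 (beyond the scatter).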

Compound 4, a percentage reported as inhibition, at one concentration (the size of the read-out at that concentration, not a potency): 21.2%
Beside the measured number, compound 4's estimate is 0.8 percentage points above it, within the range that was stated.
By their numbers in this assay, from the lowest: compound 4; then compound 3; then compound 2; then compound 1.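

Cyclopropyl on a saturated chain carbon bound to an aromatic nitrogen shows that removing the aromatic ring there continues the downward run in this assay (a number 11.5 percentage points lower from compound 3 to compound 4 (beyond the scatter)) without taking the reading to nothing. Among these compounds, all three substituted phenyl groups stand above cyclopropyl, with wider gaps at (a number 23.2 percentage points lower from compound 2 to compound 4 (beyond the scatter)) and (a number 35.1 percentage points lower from compound 1 to compound 4 (beyond the scatter)), the last being the only large step in the set. Nothing on hand accounts for these differences.

Open, from the compounds shown here alone, is whether an unsubstituted benzyl or a longer alkyl chain at this position would read nearer the substituted phenyl groups or nearer cyclopropyl.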